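Working notes: chloro added to compound 2

A few compounds are considered here, and "the series" means these few. Any claim that something is new, unique, unknown or untested is made for them only; others in the source may bear on it.

Measured so far:
compound 1 `Cc1ccccc1N(C)C(=O)c1ccc(-c2ccc(O)c(Cl)c2)o1`: 55%
compound 2 `Cc1ccccc1N(C)C(=O)c1ccc(-c2ccc(OS(N)(=O)=O)cc2)o1`: 11.7%

In a toxicity assay on HEK293 cells (Homo sapiens) for inhibition, read by MTT assay, with a stated time of 48 h, tested at 20 uM (a lower number here means less inhibition, a higher number more inhibition at the concentration tested (going by the name of the read-out)), compound 1 gives 55% while compound 2 gives 11.7%, the lower of the two numbers and beyond the scatter below compound 1. Compound 3 `Cc1ccccc1N(C)C(=O)c1ccc(-c2ccc(OS(N)(=O)=O)c(Cl)c2)o1` is not yet measured; it differs from compound 2 by chloro in place of hydrogen on an aromatic carbon. Within the data shown here, no measured pair isolates this change, so a small upward step is expected, possibly not beyond the scatter. The step of a number 8.3 percentage points higher from compound 2 to compound 3 (within the scatter) is estimated as modest. Compound 3 is expected to give 20% in this assay, with a range from 5% to 40%.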

Compound 3, a percentage reported as inhibition, at one concentration (the size of the read-out at that concentration, not a potency): 55%
Compound 3: middle estimate off by 35 percentage points, on the low side; measured number above the stated range.
By their numbers in this assay, from the lowest: compound 2; then compounds 1 and 3 (each within the scatter of the next).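

In this assay chloro in place of hydrogen on an aromatic carbon, ortho to a sulfamoyloxy group, gives a number 43.3 percentage points higher from compound 2 to compound 3 (beyond the scatter) and so marks this position as sensitive to that change. With the chloro present, sulfamoyl in place of hydrogen on the oxygen gives no change at the digits printed from compound 1 to compound 3 (within the scatter) and so does not separate the hydroxy and sulfamoyloxy forms in this read-out. Nothing available accounts for the chloro step.

On these data alone, whether fluoro, methyl or an amine on the same carbon would match chloro remains open. Also open, as far as these compounds go, is whether the chloro step recurs on another core.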